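Pyridin-2-yl replaces 5-carbamoyl-2-fluorophenyl on an amide-type nitrogen

This account rests on a few compounds, and the source may have more. Where it says the series, first, only, none or still open, it means among the compounds named here.

In an ADME assay on LLC-MK2 cells (Macaca mulatta) for cytotoxicity, read by spectrophotometry and crystal violet staining, with a stated time of 4 days (a higher number here means that more compound is tolerated, a lower number that less compound is tolerated), compound 1 `CC(C)n1ncc2c(C(=O)Nc3ccc(F)cc3)cc(-c3cccs3)nc21` gives > 200000 nM, which is a limit of the assay and not a number. Among the measured compounds shown here, compound 2 `CC(C)n1ncc2c(C(=O)Nc3cc(C(N)=O)ccc3F)cc(-c3cccs3)nc21` gives 25000 nM, the only actual number so far. Compound 2 can therefore be placed only against the limit of compound 1. The next compound, compound 3 `CC(C)n1ncc2c(C(=O)Nc3ccccn3)cc(-c3cccs3)nc21`, carries pyridin-2-yl in place of 5-carbamoyl-2-fluorophenyl on an amide-type nitrogen. For the measured compounds named here, the one measured step that bears on this change is an at least 8.0-fold lower number from compound 1 to compound 2 (0.90 log units; beyond the scatter), which brought in the very group that now leaves, so a return towards higher numbers is expected in this assay. Pyridin-2-yl itself has not been measured in this series, so that return may be only partial. The expected change is a 3.6-fold higher number from compound 2 to compound 3 (0.56 log units; beyond the scatter). For compound 3 the estimated value is 90000 nM, within an expected range of 30000 nM to 200000 nM.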

Compound 3, half-maximal cytotoxic concentration: > 200000 nM
Compound 3: only a limit was reported; the forecaster's own chance of this, stated with the estimate: 40%; middle value at least 2.2-fold (0.34 log units) away from the limit.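

In this assay the exchange on the amide-type nitrogen gives an at least 8.0-fold higher number from compound 2 to compound 3 (0.90 log units; beyond the scatter) and shows that the lower number of compound 2 does not carry over to pyridin-2-yl. Of the three groups shown at this place, only 5-carbamoyl-2-fluorophenyl goes with an actual number, while 4-fluorophenyl and pyridin-2-yl both go with a limit and not a number. The step between compound 1 and compound 3 cannot be read, because both sit at the same limit: the limit of > 200000 nM in this assay, at which 2 of the 3 values shown sit.

On these data alone, what stays open is how far below that limit other groups at this place would fall, and whether the carbamoyl or the fluorine of 5-carbamoyl-2-fluorophenyl goes with the lower number. A carboxylic acid or a nitrile in place of the carbamoyl, or an amine on the pyridin-2-yl ring, remains untested among the compounds shown here.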